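A Second Hydroxy Group on a Compound at the Limit

The source may hold more compounds than are shown below. What is called first, only, known or untested is meant among the compounds shown, and "the series" means these compounds.

In a functional assay on SK-MEL cells (Homo sapiens) for cytotoxicity, read by MTT assay, with a stated time of 6 days (a higher number here means that more compound is needed for the effect, a lower number that less compound is needed), compound 1 (`COc1ccc2oc(-c3ccc(O)cc3)c(C(=O)O)c(=O)c2c1`) gives > 25 ug/mL as a limit of the assay and not a number. Compound 2 (`O=c1cc(-c2ccc([N+](=O)[O-])cc2)oc2cc(O)ccc12`) gives > 25 ug/mL in this assay as a limit too, so it has no exact value. Both compounds therefore sit at the same limit (the limit of > 25 ug/mL in this assay, at which 2 of the 2 values shown sit) and cannot be ranked against each other. Compound 3 (`O=c1cc(-c2ccc([N+](=O)[O-])cc2)oc2c(O)c(O)ccc12`) differs from compound 2 by one change, hydroxy in place of hydrogen on an aromatic carbon in the form of hydroxy in place of hydrogen on an aromatic carbon, ortho to a hydroxy group. Among the compounds with values here, no measured pair shows what this change does, so any forecast is loose. A modest move towards less compound needed is expected, shown as the estimated at least 1.2-fold lower number from compound 2 to compound 3 (0.09 log units; that floor lies within the scatter) here, and another limit remains quite possible. In this assay compound 3 is estimated at 20 ug/mL with an expected range from 8 ug/mL to 45 ug/mL around that figure.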

Compound 3, concentration for half-maximal effect: 3.29 ug/mL
Compound 3: middle estimate off by 6.1-fold (0.78 log units), on the high side, and the stated range ends above it.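

In this assay hydroxy in place of hydrogen on an aromatic carbon, ortho to a hydroxy group, gives an at least 7.5-fold lower number from compound 2 to compound 3 (0.88 log units; beyond the scatter) and the first exact value among the compounds shown. This carbon of the shared core is therefore a place where one added hydroxy group is enough to move a compound off the limit. As far as these compounds go, compound 2 gives > 25 ug/mL as a limit of the assay and not a number, so the step is only a floor and its true size stays unknown: the limit of > 25 ug/mL in this assay, at which 2 of the 3 values shown sit.

Open, from the compounds shown here alone, is whether hydroxy itself is needed at this carbon, or whether an amine or a fluorine atom there would do the same. Also open, going by these compounds, is whether the step survives when another group, such as a carboxylic acid, replaces the nitro group on the shared core.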